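Piperidine ester series: cytotoxicity notes on compound 3

A few compounds are considered here, and "the series" means these few. Any claim that something is new, unique, unknown or untested is made for them only; others in the source may bear on it.

Measured so far:
compound 1, `CC1(C)[C@H]2CC[C@]1(C)[C@H](OC(=O)CN1CCCCC1)C2`: 141000 nM
compound 2, `CC1(C)[C@H]2CC[C@]1(C)[C@H](OC(=O)CCCCN1CCCCC1)C2`: 101000 nM

For the measured compounds named here, both measured compounds carry the same core and a piperidin-1-yl ester; compound 2 differs from compound 1 in the length of the chain between the ester and the ring nitrogen, and no step is computed for that pair. In an ADME assay on HEK-293T cells (Homo sapiens) for cytotoxicity, read by MTT assay, with a stated time of 48 h (a higher number here means that more compound is tolerated, a lower number that less compound is tolerated), compound 1 gives 141000 nM, and compound 2 gives 101000 nM. The two numbers lie within the scatter of each other, so the series as read so far shows no resolved difference between its members.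

Compound 3, `CC1CCN(CC(=O)O[C@@H]2C[C@@H]3CC[C@@]2(C)C3(C)C)CC1`, has not yet been measured. It differs from compound 1 in one place: methyl in place of hydrogen on a saturated ring carbon. Read one bond further out, the change is piperidin-1-yl to 4-methylpiperidin-1-yl.

Going by the values given here, no measured step is available to anchor this change, and the two known values leave little room for a resolved effect. The expected step of a 1.1-fold lower number from compound 1 to compound 3 (0.04 log units; within the scatter) is therefore none beyond the scatter. For compound 3 the estimated value in this assay is 130000 nM, with a range from 60000 nM to 280000 nM.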

Compound 3, half-maximal cytotoxic concentration: 71600 nM
The estimate for compound 3 lay 1.8-fold (0.26 log units) above the measured number, and the stated range covers the measured number.
By their numbers in this assay, from the lowest: compounds 3, 2 and 1 (each within the scatter of the next).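

In this assay the methyl sits on a saturated ring carbon, three ring bonds from the ring nitrogen, and the series now has its first measured single-place step: a 2.0-fold lower number from compound 1 to compound 3 (0.29 log units; within the scatter) with methyl in place of hydrogen. For the compounds shown here, the earlier pair differed only in chain length and gave no computed step, whereas this result isolates one ring position on the shared core. At this position, the change from piperidin-1-yl to 4-methylpiperidin-1-yl gives no resolved shift in tolerated concentration, and no measurement at hand bears on the origin of this step.

The compounds shown leave open whether an ethyl group, a phenyl ring, a hydroxyl group or an amine on the same ring carbon would give a step beyond the scatter in this assay or stay within it. Also open, going by these compounds, is whether methyl on another carbon of the piperidine ring, or 4-methylpiperidin-1-yl carried on the longer chain of compound 2, would read the same way.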